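Removing the cyclobutyl group from compound 2

A few compounds are considered here, and "the series" means these few. Any claim that something is new, unique, unknown or untested is made for them only; others in the source may bear on it.

Compound 1: `Cn1c(-c2ccccc2)nc2c(NC3CCCC3)ncnc21`, 846 nM
Compound 2: `CCn1c(-c2ccccc2)nc2c(NC3CCC3)ncnc21`, 84 nM

Going by the values given here, compound 2 has the lower of the two numbers measured so far. In an assay on CHO cells for displacement of a labelled ligand from adenosine receptor A3 (Homo sapiens), read by scintillation counting, with a stated time of 3 h (a lower number here means a stronger inhibitor, a higher number a weaker inhibitor), compound 2 gives 84 nM, while compound 1 gives 846 nM, a gap beyond the usual scatter. Compound 3, `CCn1c(-c2ccccc2)nc2c(N)ncnc21`, has not yet been measured; it differs from compound 2 in one place: hydrogen in place of cyclobutyl on a nitrogen on an aromatic ring. Among the compounds with values here, no pair of measured compounds differs in a single place, so this change has no direct precedent here. Compound 3 is expected to be a weaker inhibitor, with a step of an 18-fold higher number from compound 2 to compound 3 (1.25 log units; beyond the scatter), and an estimated value of 1500 nM within 300 nM to 8000 nM.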

Compound 3, inhibition constant: 5780 nM
For compound 3 the middle estimate is 3.9-fold (0.59 log units) below the measured one; measured number inside the range.
By their numbers in this assay, from the lowest: compound 2; then compound 1; then compound 3.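

In this assay, going by these compounds alone, the change from cyclobutylamino to amino gives a 69-fold higher number from compound 2 to compound 3 (1.84 log units; beyond the scatter) and is the first single-place change that can be read. It shows that the cyclobutyl group on this nitrogen goes with a much lower number than hydrogen does, at least on the core of compound 2. Nothing at hand explains the size of this step.

From the compounds shown here alone, whether methyl, cyclohexyl or a longer chain on this nitrogen would match compound 2 remains open. So does whether a hydroxyl on the cyclobutyl ring would keep its number.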